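Aryl variation on the piperazine nitrogen, toward phenyl

The source may report more compounds than this note shows. Statements on the series, on what has been measured and on what is new or still open speak of the compounds shown alone.

Three compounds of this series carry the same core and differ only in the aryl group on the amine nitrogen of the piperazine. In an assay on HEK293 cells for inhibition of Voltage-dependent T-type calcium channel subunit alpha-1G (Homo sapiens), read by fluorescence, tested at 10 uM (on this read-out higher numbers stand for more inhibition at the one concentration tested (going by the name of the read-out) and lower numbers for less inhibition), compound 1 `CCCc1nc(-c2ccccc2)c(CNCCN2CCN(c3ccc(Cl)cc3)CC2)o1` gives 55.8%. Compound 2 `CCCc1nc(-c2ccccc2)c(CNCCN2CCN(c3ccccc3C(F)(F)F)CC2)o1` gives 54.6%; the step of a number 1.2 percentage points lower from compound 1 to compound 2 (within the scatter) is within the usual scatter. Compound 3 `CCCc1nc(-c2ccccc2)c(CNCCN2CCN(c3cccc(C)c3C)CC2)o1` gives 66.7% and stands highest of the three, with a number 10.9 percentage points higher from compound 1 to compound 3 (beyond the scatter) and a number 12.1 percentage points higher from compound 2 to compound 3 (beyond the scatter) both beyond the scatter.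

Compound 4 `CCCc1nc(-c2ccccc2)c(CNCCN2CCN(c3ccccc3)CC2)o1` is the unmeasured member; compared with compound 3 the change is phenyl in place of 2,3-dimethylphenyl on an amine nitrogen in a ring. Among the measured compounds shown here, two measured steps bear on it: both of the other aryl groups, 4-chlorophenyl in compound 1 and 2-(trifluoromethyl)phenyl in compound 2, fall below 2,3-dimethylphenyl by a modest margin beyond the scatter, while the two lower compounds sit within the scatter of each other. Phenyl is the least substituted aryl of the set and has no measured neighbour, so the expectation for compound 4 is a modest drop, a number 14.7 percentage points lower from compound 3 to compound 4 (beyond the scatter), back toward the level of compound 1 and compound 2. Compound 4 is therefore estimated at 52%, in a range from 38% to 66%.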

Compound 4, a percentage reported as inhibition, at one concentration (the size of the read-out at that concentration, not a potency): 54.3%
Estimate against measurement, compound 4: 2.3 percentage points below, within the range that was stated.
By their numbers in this assay, from the lowest: compounds 4, 2 and 1 (each within the scatter of the next); then compound 3.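

Among the compounds shown here, with the plain phenyl of compound 4 now in hand, 2,3-dimethylphenyl can be set against the unsubstituted ring in this assay: the change reads as a number 12.4 percentage points lower from compound 3 to compound 4 (beyond the scatter) and is the only step to this aryl group that lies beyond the scatter. Hydrogen in place of trifluoromethyl gives a number 0.3 percentage points lower from compound 2 to compound 4 (within the scatter) and hydrogen in place of chloro gives a number 1.5 percentage points lower from compound 1 to compound 4 (within the scatter) in the same read-out, so neither of these two substituents, each at its own place on the ring, separates from the unsubstituted phenyl here, and among the four compounds only 2,3-dimethylphenyl stands apart. No supporting data bear on what lies behind the separate position of 2,3-dimethylphenyl.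

Going by these compounds, whether a single methyl on the phenyl would reach the level of compound 3, or both methyl groups are needed, stays open, as does the outcome for a methoxy group on the phenyl or a pyridine ring in its place. On these data alone, all four numbers are inhibition at a single concentration in this assay, so how the aryl groups rank in potency also remains open.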